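This account rests on a few compounds, and the source may have more. Where it says the series, first, only, none or still open, it means among the compounds named here.

In a physicochemical assay for lipophilicity, read by HPLC, at pH 7.4 (on this read-out lower numbers stand for lower lipophilicity and higher numbers for higher lipophilicity), compound 2 (`Cc1ccccc1N1C(=O)/C(=C/c2ccc(O)c(Cl)c2)S/C1=N\CCO`) gives 1.9 and holds the lower of the two numbers in the series. Compound 1 (`CCC/N=C1\S/C(=C\c2ccc(O)c(C(F)(F)F)c2)C(=O)N1c1ccccc1C`) gives 3.8 as the other number, and its gap to compound 2 lies beyond the scatter. Compound 3 (`CCC/N=C1\S/C(=C\c2ccc(O)c(Cl)c2)C(=O)N1C(C)C`) reads > 4.3 as a limit of the assay and not a number, so it offers no exact comparison.

Compound 4 (`Cc1ccccc1N1C(=O)/C(=C/c2ccc(O)c(Cl)c2)S/C1=N\CCCF`) has not yet been measured. Its change from compound 2 is fluoromethyl in place of hydroxy on a saturated chain carbon, two bonds along the chain from a double-bonded nitrogen and the same difference reads 2-hydroxyethyl to 3-fluoropropyl.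

Going by the values given here, no measured pair isolates this change, so the size of the step remains a judgement. Compound 1 at 3.8 also has no hydroxy on its chain, but it differs from compound 2 in a further place and serves only as a rough guide. Expected in this assay is an upward step of a number 1.30 log units higher from compound 2 to compound 4 (beyond the scatter) that would lie beyond the scatter. For compound 4 the estimated value is 3.2 with an expected range from 2.6 to 3.8 on this read-out.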

Compound 4, distribution coefficient: 3.4
Estimate against measurement, compound 4: 0.20 log units below; the range from low to high includes it.
By their numbers in this assay, from the lowest: compound 2; then compound 4; then compound 1. At a limit, above all of these: compound 3.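

In this assay, the change from 2-hydroxyethyl to 3-fluoropropyl, on a saturated chain carbon, two bonds along the chain from a double-bonded nitrogen, gives a number 1.50 log units higher from compound 2 to compound 4 (beyond the scatter), a large step and the first in the series that can be read in one place. The earlier compounds shown here differ from one another in more than one place, so they could not tie any shift to this chain; here the rest of the structure is held fixed, which shows that this position alone can move the read-out by a large amount. Compound 3 remains a limit and not a number, so it adds no step to this picture, and the read-out has a ceiling in this series: the limit of > 4.3 in this assay, at which 1 of the 4 values shown sits.

Going by these compounds alone, the single pair swaps hydroxy for fluoromethyl as one change, so it does not separate the part of the step that goes with the fluorine from the part that goes with the extra chain carbon; a 3-hydroxypropyl or a 2-fluoroethyl chain at this place would divide the two. From the compounds shown here alone, how an amine or a carboxylic acid at the end of this chain would read remains open.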